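Swapping trifluoroethyl for acetyl on a naphthyl-furan scaffold

The compounds below may be only part of what the source reports. "The series", "measured", "known", "first", "only" and "open" are said of these compounds alone.

Measured compounds:
- Compound 1, `CCc1cccc2c(OC(C)=O)c(-c3occ(C)c3COC(C)=O)ccc12`: in a functional assay on A549 cells (Homo sapiens) for cytotoxicity, read by MTT assay, with a stated time of 72 h (on this read-out higher numbers stand for an effect only at larger amounts of compound and lower numbers for an effect already at smaller amounts), compound 1 gives > 10 ug/mL, which is a limit of the assay and not a number.
- Compound 2, `CCOCc1c(C)coc1-c1ccc2c(CC)cccc2c1OC`: in this assay compound 2 gives > 10 ug/mL, again a limit of the assay.
- Compound 3, `CCc1cccc2c(OC)c(-c3occ(C)c3COCC(F)(F)F)ccc12`: in this assay compound 3 gives > 10 ug/mL, also a limit of the assay.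

So compound 3 stands where every measured compound stands, at the limit of > 10 ug/mL in this assay, at which 3 of the 3 values shown sit. Among the measured compounds shown here, no compound has yet been read as a number in this assay, and the one change with measured ends, a step that the two limits leave unreadable from compound 2 to compound 3, cannot be sized for that reason.

Compound 4, `CCc1cccc2c(OC)c(-c3occ(C)c3COC(C)=O)ccc12`, differs from compound 3 in one place: acetyl in place of 2,2,2-trifluoroethyl on an oxygen on a saturated carbon. Compound 1 carries this same acetoxymethyl group and sits at the same limit, and compound 3 is itself at that limit, so nothing measured points to a reading below it. The step that the limit leaves unreadable from compound 3 to compound 4 is therefore expected to stay inside the usual scatter. Compound 4 is estimated at 20 ug/mL, with a likely range from 8 ug/mL to 60 ug/mL, most probably reported once more as a limit.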

Compound 4, concentration for half-maximal effect: > 10 ug/mL
Compound 4: only a limit was reported; the forecaster's own chance of this, stated with the estimate: 85%; the middle value is on the limit's open side.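

In this assay compound 4 gives > 10 ug/mL, a limit and not a number. The steps to compound 4 from compound 1, compound 2 and compound 3 therefore cannot be read: the limit of > 10 ug/mL in this assay, at which 4 of the 4 values shown sit. From the compounds shown here alone, whether any of these changes alters cytotoxicity at all stays open.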